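The source may report more compounds than this note shows. Statements on the series, on what has been measured and on what is new or still open speak of the compounds shown alone.

Measured compounds in a functional assay on MT4 cells (Homo sapiens) for cytotoxicity; a lower number here means that less compound is tolerated, a higher number that more compound is tolerated:

compound 1 `CC(=O)O[C@H]1[C@H](n2cc(C)c(=O)[nH]c2=O)O[C@H](COC(=O)c2ccccc2)[C@@]12OS(=O)(=O)C=C2N`: > 200000 nM (a limit of this assay, not a number)
compound 2 `CC(C)(C)[Si](C)(C)OC[C@H]1O[C@@H](n2ccc(=O)[nH]c2=O)[C@H](O[Si](C)(C)C(C)(C)C)C12OS(=O)(=O)C=C2N`: 15000 nM
compound 3 `Cc1cn([C@@H]2O[C@H](CO)[C@@]3(OS(=O)(=O)C=C3N)[C@H]2O[Si](C)(C)C(C)(C)C)c(=O)[nH]c1=O`: 229000 nM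

Compound 3 holds the higher of the two numbers given in this assay. The nearest number is that of compound 2, which gives 15000 nM in this assay, a gap that lies beyond the usual scatter. For compound 1 only a limit is recorded, (the limit of > 200000 nM in this assay, at which 1 of the 3 values shown sits), so its value in this assay is not a number.

Compound 4 `Cc1cn([C@@H]2O[C@H](COC(=O)c3ccccc3)[C@@]3(OS(=O)(=O)C=C3N)[C@H]2O[Si](C)(C)C(C)(C)C)c(=O)[nH]c1=O` differs from compound 3 in one place: benzoyl in place of hydrogen on an oxygen on a saturated carbon. Within the data shown here, no step between two measured compounds covers this change. Compound 1, which also carries a benzoyl ester on the hydroxymethyl oxygen, sits at the limit (the limit of > 200000 nM in this assay, at which 1 of the 3 values shown sits), and compound 3 already sits high in this assay, so no step beyond the scatter is expected. Compound 4 is expected to reach 200000 nM, estimated between 60000 nM and 600000 nM, with the expected step being a 1.1-fold lower number from compound 3 to compound 4 (0.06 log units; within the scatter); a limit rather than a number is a real possibility.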

Compound 4, half-maximal cytotoxic concentration: 36000 nM
The estimate for compound 4 lay 5.6-fold (0.74 log units) above the measured number; measured number below the stated range.
By their numbers in this assay, from the lowest: compound 2; then compound 4; then compound 3.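

Benzoyl in place of hydrogen on an oxygen on a saturated carbon gives the first readable step at this position in this assay: a 6.4-fold lower number from compound 3 to compound 4 (0.80 log units; beyond the scatter). The benzoyl ester alone does not set the number, since a group of 7 heavy atoms (6 carbon, 1 silicon) in place of a group of 3 heavy atoms (2 carbon, 1 oxygen) on the other oxygen, with the benzoyl ester present on both sides, gives an at least 5.5-fold lower number from compound 1 to compound 4 (0.74 log units; beyond the scatter). That second step is open-ended, as the entry for compound 1 is a limit and not a number: the limit of > 200000 nM in this assay, at which 1 of the 4 values shown sits.

From the compounds shown here alone, it remains open whether the lower number follows the aromatic ring of the benzoyl group or the ester as such, which an acetyl or a longer straight-chain acyl group on the hydroxymethyl oxygen would separate. An amine or a carboxylic acid on that acyl group is equally unresolved.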